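The source may hold more compounds than are shown below. What is called first, only, known or untested is meant among the compounds shown, and "the series" means these compounds.

Measured compounds:

Compound 1 `CN1CCC(n2cc(S(=O)(=O)c3ccccc3F)c3cccnc32)C1`: in an assay on HeLa cells for displacement of a labelled ligand from 5-hydroxytryptamine receptor 6 (Homo sapiens) (on this read-out lower numbers stand for stronger inhibition and higher numbers for weaker inhibition), compound 1 gives 5.6 nM.
Compound 2 `CN1CCC(n2cc(S(=O)(=O)c3cccc(F)c3)c3cccnc32)C1`: in this assay compound 2 gives 1.4 nM.
Compound 3 `O=S(=O)(c1ccccc1F)c1cn(C2CCCNC2)c2ncccc12`: in this assay compound 3 gives 2 nM.

Compound 4 `O=S(=O)(c1cccc(F)c1)c1cn(C2CCCNC2)c2ncccc12` has not yet been measured in this assay. It differs from compound 3 in a single place: 3-fluorophenyl in place of 2-fluorophenyl on a sulfonyl sulfur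

The same change has already been made once among the measured compounds, from compound 1 to compound 2: 3-fluorophenyl in place of 2-fluorophenyl on a sulfonyl sulfur That step gave a 4.0-fold lower number from compound 1 to compound 2 (0.60 log units; beyond the scatter).

The two starting points, compound 1 and compound 3, share everything but the group on the aromatic nitrogen of the shared core: piperidin-3-yl in place of 1-methylpyrrolidin-3-yl on an aromatic nitrogen This change alone gave a 2.8-fold lower number from compound 1 to compound 3 (0.45 log units; beyond the scatter). The place where the fluorophenyl group is swapped reads the same in both pairs, a sulfonyl sulfur whose other neighbour is an aromatic carbon, so the change from compound 3 to compound 4 is the same change as that from compound 1 to compound 2, made on a core that carries a different ring on its aromatic nitrogen.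

Within the data shown here, with only one earlier example of this change, the size of the step from compound 3 to compound 4 is expected to be somewhat smaller than the earlier one, as a single step may not repeat exactly on a different core; it is estimated as a 3.3-fold lower number from compound 3 to compound 4 (0.52 log units; beyond the scatter). The expectation for compound 4 rests on compound 3 giving 2 nM and on the earlier step of a 4.0-fold lower number from compound 1 to compound 2 (0.60 log units; beyond the scatter). In this assay compound 4 is therefore expected to give about 0.6 nM, most likely between 0.25 nM and 1.5 nM.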

Compound 4, inhibition constant: 2.4 nM
The estimate for compound 4 lay 4.0-fold (0.60 log units) below the measured number, outside the stated range (above it).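

On the core that carries piperidin-3-yl, the swap from 2-fluorophenyl to 3-fluorophenyl in this assay gave a 1.2-fold higher number from compound 3 to compound 4 (0.08 log units; within the scatter), so the clear step seen on the core of compound 1 did not carry over, as setting the two side by side shows: the same change on two cores in this assay, a 4.0-fold lower number (0.60 log units; beyond the scatter) from compound 1 to compound 2 and a 1.2-fold higher number (0.08 log units; within the scatter) from compound 3 to compound 4, 4.8-fold (0.68 log units) apart, beyond the scatter of two such steps. The ring change on the aromatic nitrogen tells the same story from the other side, since with 3-fluorophenyl on the sulfonyl sulfur it gave a 1.7-fold higher number from compound 2 to compound 4 (0.23 log units; within the scatter), and the two changes therefore do not simply add up in this series: the same change on two cores in this assay, a 2.8-fold lower number (0.45 log units; beyond the scatter) from compound 1 to compound 3 and a 1.7-fold higher number (0.23 log units; within the scatter) from compound 2 to compound 4, 4.8-fold (0.68 log units) apart, beyond the scatter of two such steps. Both comparisons rest on the same four compounds, so they are one finding seen twice; they show that the step depends on the core in this set, but they do not show why, or how the swap would behave on any further core.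

The compounds shown leave open whether the swap keeps its size on a core with pyrrolidin-3-yl or 1-methylpiperidin-3-yl on the aromatic nitrogen, which would help separate the methyl group from the ring size. They also leave open how other groups on the sulfonyl sulfur, such as 4-fluorophenyl or 3-chlorophenyl, would fare on each core.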